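The compounds below may be only part of what the source reports. "The series", "measured", "known", "first", "only" and "open" are said of these compounds alone.

Compound 1 `C=C1C[C@]23C[C@@]1(O)CC[C@@H]2c1cccc(C)c1[C@@H]3Cn1cc(-c2ccc(C)cc2)nn1`: in a functional assay on SMMC-7721 cells (Homo sapiens) for cytotoxicity, read by MTT assay, with a stated time of 4 days (a lower number here means a stronger inhibitor, a higher number a weaker inhibitor), compound 1 reaches only the limit > 20000 nM, not a number.
Compound 2 `C=C1C[C@]23C[C@@]1(O)CC[C@H]2c1ccc(O)c(C)c1[C@@H]3Cn1cc(-c2ccc(F)cc2)nn1`: in this assay compound 2 likewise stops at the limit > 20000 nM.
Compound 3 `C=C1C(=O)[C@]23C[C@@]1(O)CC[C@H]2c1ccc(OS(=O)(=O)c2ccc(C)cc2)c(C)c1[C@@H]3Cn1cc(-c2ccc(F)cc2)nn1`: in this assay compound 3 gives 4280 nM.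

Among these three, compound 3 is the only one whose result is an actual number; the other two sit at the limit of > 20000 nM in this assay, at which 2 of the 3 values shown sit, so no ranking against them is possible beyond saying that compound 3 registered where they did not. Within the data shown here, compound 3 carries a ketone on its core and a tosylate on the aromatic ring, features that compound 1 and compound 2 do not share, but with only three compounds no step between measured pairs can be drawn.

Compound 4 `C=C1C(=O)[C@]23C[C@@]1(O)CC[C@H]2c1ccc(OS(=O)(=O)c2ccc(C)cc2)c(C)c1[C@@H]3Cn1cc(-c2ccccn2)nn1` keeps the whole skeleton of compound 3 and differs only at the far end of the triazole: pyridin-2-yl in place of 4-fluorophenyl on an aromatic carbon. The pyridine brings a hydrogen-bond acceptor in place of the fluorine, but nothing measured here speaks to what that does. Among the measured compounds shown here, with no comparable step to lean on, the expected change from compound 3 to compound 4 is a 1.3-fold higher number from compound 3 to compound 4 (0.11 log units; within the scatter), a shift not clearly beyond the usual scatter. Compound 4 is therefore estimated at 5500 nM in this assay, with a range from 1500 nM to 18000 nM.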

Compound 4, half-maximal inhibitory concentration: 2830 nM
Compound 4: the middle estimate sits 1.9-fold (0.29 log units) above what was measured; low and high end bracket the measured number.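

In this assay, among these compounds, setting pyridin-2-yl in place of 4-fluorophenyl on the five-membered aromatic ring with 3 nitrogen gives a 1.5-fold lower number from compound 3 to compound 4 (0.18 log units; within the scatter), the first step here that can be read between two compounds differing in one place. Among the compounds shown here, at this position, therefore, a carbon-only aromatic ring carrying fluorine and a six-membered aromatic ring with a ring nitrogen and a hydrogen-bond acceptor give values that cannot be told apart in this cell test, although the single swap cannot separate losing the fluorine from gaining the nitrogen. Nothing measured in this set offers a reason for the size of this step.

Only these two aromatic rings are shown at this position, so it remains open how a basic amine such as a dimethylaminomethyl group, a carboxylic acid or a longer alkyl chain would behave there. Compound 1 and compound 2 each differ from compound 3 in more than one place, which leaves open whether the ketone, the tosylate or another difference accounts for compound 3 and compound 4 giving actual numbers.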